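Carbonyl substituent variation on the naphthyl-pyridine acrylamide series

This account rests on a few compounds, and the source may have more. Where it says the series, first, only, none or still open, it means among the compounds named here.

Measured so far:
compound 1, `COC1CN(C(=O)/C=C/c2ccncc2-c2ccc3ccccc3c2)C1`: 100%
compound 2, `COC(=O)/C=C/c1ccncc1-c1ccc2ccccc2c1`: 102%

Going by the values given here, in an assay on a protein complex for inhibition of CDK8/Cyclin C (Homo sapiens), with a stated time of 1 h, tested at 10 uM (a lower number here means less inhibition, a higher number more inhibition at the concentration tested (going by the name of the read-out)), compound 2 gives the higher of the two numbers; its nearest neighbour is compound 1, and the one measured step, a number 2 percentage points higher from compound 1 to compound 2 (within the scatter), lies within the scatter. The numbers of compound 1 and compound 2 in this assay are therefore level within the scatter at the tested concentration.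

Compound 3, `O=C(/C=C/c1ccncc1-c1ccc2ccccc2c1)NC1CC1`, differs from compound 2 by cyclopropylamino in place of methoxy on a carbonyl carbon. Among the compounds with values here, the only step that bears on this change is the exchange at the same carbonyl carbon, a number 2 percentage points higher from compound 1 to compound 2 (within the scatter), which moved the number by a margin within the scatter. Compound 3 is therefore expected to show no step beyond the scatter, a number 4 percentage points lower from compound 2 to compound 3 (within the scatter), in this assay. Compound 3 is estimated at 98%, with a range from 85% to 106%.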

Compound 3, a percentage reported as inhibition, at one concentration (the size of the read-out at that concentration, not a potency): 102%
The estimate for compound 3 lay 4 percentage points below the measured number; measured number inside the range.
By their numbers in this assay, from the lowest: compounds 1, 2 and 3 (each within the scatter of the next).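

In this assay, cyclopropylamino brings a hydrogen-bond donor and a three-membered ring to the carbonyl carbon, yet the exchange for methoxy gives no change at the digits printed from compound 2 to compound 3 (within the scatter). The exchange for 3-methoxyazetidin-1-yl gives a number 2 percentage points higher from compound 1 to compound 3 (within the scatter), so all three groups tested on this carbonyl carbon are level within the scatter, and this position has not yet shown a step beyond it. No available evidence bears on why these groups read alike.

On these data alone, whether a carboxylic acid or a longer alkyl chain on this carbonyl carbon would move the number beyond the scatter remains open. Also open, as far as these compounds go, is whether compounds level at this single concentration differ in potency, since this read-out does not measure potency.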